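Branching the sulfonamide nitrogen in diisopropylphenyl sulfonylureas

The compounds below may be only part of what the source reports. "The series", "measured", "known", "first", "only" and "open" are said of these compounds alone.

In an assay on liver for inhibition of sterol O-acyltransferase 1 (Rattus norvegicus), using microsomes (a lower number here means a stronger inhibitor, a higher number a weaker inhibitor), compound 3 `C=CCN(CC=C)S(=O)(=O)NC(=O)Nc1c(C(C)C)cccc1C(C)C` gives 2700 nM. Compound 2 `C=CCN(CC)S(=O)(=O)NC(=O)Nc1c(C(C)C)cccc1C(C)C` gives 2100 nM and compound 1 `CC(C)c1cccc(C(C)C)c1NC(=O)NS(=O)(=O)N(C)C` gives 3900 nM; the steps of a 1.3-fold higher number from compound 2 to compound 3 (0.11 log units; within the scatter) and a 1.4-fold lower number from compound 1 to compound 3 (0.16 log units; within the scatter) both lie within the scatter, so compound 3 is indistinguishable from either. Compound 4 `CC(C)c1cccc(C(C)C)c1NC(=O)NS(=O)(=O)N(C(C)C)C(C)(C)C` carries isopropyl(tert-butyl)amino in place of diallylamino on a sulfonyl sulfur. Within the data shown here, the steps that bear on this position, a 1.9-fold lower number from compound 1 to compound 2 (0.27 log units; within the scatter), a 1.4-fold lower number from compound 1 to compound 3 (0.16 log units; within the scatter) and a 1.3-fold higher number from compound 2 to compound 3 (0.11 log units; within the scatter), all swap substituents on that sulfonamide nitrogen and none moves beyond the scatter, so no step beyond the scatter is expected for compound 4, that is no change at the digits printed from compound 3 to compound 4 (within the scatter). Compound 4 is therefore estimated at 2700 nM in this assay, with a range from 1100 nM to 6500 nM.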

Compound 4, half-maximal inhibitory concentration: 140 nM
Compound 4: middle estimate off by 19-fold (1.29 log units), on the high side, and the stated range ends above it.
By their numbers in this assay, from the lowest: compound 4; then compounds 2, 3 and 1 (each within the scatter of the next).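

Isopropyl(tert-butyl)amino on the sulfonyl sulfur stands apart from all three earlier amino groups in this assay, with a 19-fold lower number from compound 3 to compound 4 (1.29 log units; beyond the scatter) and a 15-fold lower number from compound 2 to compound 4 (1.18 log units; beyond the scatter) and a 28-fold lower number from compound 1 to compound 4 (1.44 log units; beyond the scatter). Thus a position that stayed within the scatter across dimethylamino, allyl(ethyl)amino and diallylamino can respond strongly to the groups on this sulfonamide nitrogen. Nothing available here accounts for this difference. The compounds shown leave open whether isopropyl or tert-butyl matters more, and whether diisopropylamino or ethyl(tert-butyl)amino would give a similarly low number.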